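A meta substituent swap: ethyl for bromo

The source may hold more compounds than are shown below. What is called first, only, known or untested is meant among the compounds shown, and "the series" means these compounds.

Of the compounds shown here, three sharing one core have been measured in an assay on microsomes from liver for inhibition of acyl-CoA desaturase 1 (Rattus norvegicus); on this read-out higher numbers stand for weaker inhibition and lower numbers for stronger inhibition. Compound 1 `Cc1ccc(OC2CCN(c3ccc(-n4ccnc4)nn3)CC2)cc1` gives 527 nM. Compound 2 `c1cc2c(c(OC3CCN(c4ccc(-n5ccnc5)nn4)CC3)c1)CCC2` gives 10 nM, and compound 3 `Brc1cccc(OC2CCN(c3ccc(-n4ccnc4)nn3)CC2)c1` gives 23 nM. The step of a 53-fold lower number from compound 1 to compound 2 (1.72 log units; beyond the scatter) and the step of a 23-fold lower number from compound 1 to compound 3 (1.36 log units; beyond the scatter) show that replacing 4-methylphenyl with a different aryl group on the oxygen shifts the read-out strongly, while the step of a 2.3-fold higher number from compound 2 to compound 3 (0.36 log units; beyond the scatter) is only modest. Compound 3 therefore stands second of the three, with compound 2 nearest and compound 1 furthest away.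

Compound 4 `CCc1cccc(OC2CCN(c3ccc(-n4ccnc4)nn3)CC2)c1` differs from compound 3 by ethyl in place of bromo on an aromatic carbon, on an aromatic carbon of a six-membered aromatic ring of carbon only, meta to a large group. Among the compounds with values here, no measured pair tests this exact exchange; the steps from compound 1 and compound 2 to compound 3 concern other aryl groups entirely. Since bromo and ethyl are both small, neutral groups placed on the same ring position, a step of a 1.3-fold higher number from compound 3 to compound 4 (0.12 log units; within the scatter) is expected, which is within the usual scatter. Compound 4 is thus estimated at 30 nM, with a range from 10 nM to 90 nM.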

Compound 4, half-maximal inhibitory concentration: 38 nM
The estimate for compound 4 lay 1.3-fold (0.10 log units) below the measured number, and the stated range covers the measured number.
By their numbers in this assay, from the lowest: compound 2; then compounds 3 and 4 (each within the scatter of the next); then compound 1.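

In this assay, ethyl in place of bromo on an aromatic carbon of this ring, meta to a large group, gives a 1.7-fold higher number from compound 3 to compound 4 (0.22 log units; within the scatter), the first direct test at this position of one group against another on the same aryl ring. The 3-ethylphenyl group also keeps a large separation from 4-methylphenyl, seen in a 14-fold lower number from compound 1 to compound 4 (1.14 log units; beyond the scatter), so this separation is now seen with two different groups at this position rather than with bromo alone. Within the data shown here, the 2,3-dihydro-1H-inden-4-yl group still gives the lowest number of the four, as a 3.8-fold higher number from compound 2 to compound 4 (0.58 log units; beyond the scatter) shows, and this step lies beyond the scatter, as does the one from compound 2 to compound 3.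

The compounds shown leave open whether a longer chain such as propyl, or an amine or a carboxylic acid, would read like ethyl and bromo on this carbon. Since 4-methylphenyl differs from 3-ethylphenyl in both the group and its place on the ring, they also do not separate the part played by each of these two changes. Nothing shown explains why ethyl and bromo read alike here.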